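The source may report more compounds than this note shows. Statements on the series, on what has been measured and on what is new or still open speak of the compounds shown alone.

Four compounds built on one shared core are considered here, three of them already measured in an assay on isolated protein for binding affinity to sphingosine 1-phosphate receptor 2 (Homo sapiens), read by surface plasmon resonance; a higher number here means weaker binding, a lower number tighter binding. Compound 2 `CCCc1cc(NNC(=O)Nc2cc(Cl)nc(Cl)c2)nc2c1cnn2C` holds the lowest of the three numbers, giving 1400 nM. Compound 3 `Cc1nn(C)c2nc(NNC(=O)Nc3cc(Cl)nc(Cl)c3)cc(C3CC3)c12` gives 3650 nM, and compound 1 `Cn1ncc2c(-c3ccc(F)cc3)cc(NNC(=O)Nc3cc(Cl)cc(Cl)c3)nc21` gives 4980 nM; both of these gaps from compound 2 lie beyond the usual scatter of this assay. Within the data shown here, neither compound 1 nor compound 3 differs from compound 2 in a single place, so no single-change step between measured compounds is available to lean on.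

The unmeasured compound 4 `COc1ccc(-c2cc(NNC(=O)Nc3cc(Cl)nc(Cl)c3)nc3c2cnn3C)cc1` differs from compound 2 in one place only: 4-methoxyphenyl in place of propyl on an aromatic carbon. Among the measured compounds shown here, with no comparable step among the measured compounds, the direction of this change can only be guessed. Compound 1 gives the weakest of the three numbers and carries an aryl group rather than a chain, but it also differs from compound 2 elsewhere, so it is no clean guide.

The chemist expects a small to moderate weakening, of a size a 1.8-fold higher number from compound 2 to compound 4 (0.25 log units; within the scatter), though a result within the scatter would not surprise. Compound 4 is estimated at 2500 nM, with a range from 800 nM to 8000 nM.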

Compound 4, dissociation constant: 520 nM
Beside the measured number, compound 4's estimate is 4.8-fold (0.68 log units) above it; measured number below the stated range.
By their numbers in this assay, from the lowest: compound 4; then compound 2; then compounds 3 and 1 (each within the scatter of the next).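

In this assay, among these compounds, the single-change step reads a 2.7-fold lower number from compound 2 to compound 4 (0.43 log units; beyond the scatter), the first direct comparison at this position, which lies on an aromatic carbon opposite the ring nitrogen. It shows that 4-methoxyphenyl in place of propyl, a larger group that brings one six-membered aromatic ring and one hydrogen-bond acceptor, is compatible with tighter binding here, by a margin beyond the scatter; compound 1 also carries an aryl group at this place, but it differs from compound 2 elsewhere as well and could not show this. The compounds offer no independent evidence that would explain the step.

On these data alone, it remains open whether the aromatic ring or the methoxy group accounts for the change, a question that unsubstituted phenyl, a pyridine ring or 4-hydroxyphenyl at this position could help to settle, while a longer chain such as pentyl would test whether size alone goes with the same shift. As far as these compounds go, it is also open whether the same exchange would give a similar step on the core of compound 3, which carries a further methyl group and a cyclopropyl group at this place.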